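Adding a Methyl to a Cytotoxicity-Limited Scaffold

The source may hold more compounds than are shown below. What is called first, only, known or untested is meant among the compounds shown, and "the series" means these compounds.

Compound 1, `CC1(C)OC(=O)C2(C(=O)O1)[C@@H](c1ccco1)CC(=O)C[C@H]2c1ccco1`, and compound 2, `COc1ccc([C@@H]2CC(=O)C[C@H](c3ccco3)C23C(=O)OC(C)(C)OC3=O)cc1`, share one core. In an ADME assay on MT2 cells (Homo sapiens) for cytotoxicity (on this read-out lower numbers stand for higher toxicity in this test and higher numbers for lower toxicity in this test), compound 1 reaches only a limit, > 111000 nM. In this assay compound 2 likewise gives only a limit, > 111000 nM. The step between them, a step that the two limits leave unreadable from compound 1 to compound 2, therefore cannot be read, because the limit of > 111000 nM in this assay, at which 2 of the 2 values shown sit, places both where the test stops counting. Compound 3, `COc1ccc([C@@H]2CC(=O)C[C@H](c3ccco3)C23C(=O)OC(C)(C)OC3=O)c(C)c1`, differs from compound 2 by methyl in place of hydrogen on an aromatic carbon. Within the data shown here, no measured step bears on this change; the only comparison available is unreadable. The entering methyl on the six-membered aromatic ring of carbon only is not expected to move compound 3 out of the region where both measured compounds already stand, so the expected step of a number no higher from compound 2 to compound 3 (the limit leaves the size open) is none beyond the scatter. Compound 3 is thus estimated at 111000 nM, between 40000 nM and 300000 nM, most likely again reported only as a limit.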

Compound 3, half-maximal cytotoxic concentration: > 111000 nM
Compound 3: only a limit was reported; the forecaster's own chance of this, stated with the estimate: 75%; the middle value sits exactly at the limit.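

Compound 3 gives only the limit > 111000 nM in this assay and no exact number. Among these compounds, with that, no step among compound 1, compound 2 and compound 3 can be read. The compounds shown leave open where the actual cytotoxic concentration of each lies, and whether the methyl shifts it at all.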